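Trifluoromethoxy in Place of Chloro: One Step, One Estimate

The source may hold more compounds than are shown below. What is called first, only, known or untested is meant among the compounds shown, and "the series" means these compounds.

Compound 1 `Nc1ccccc1NC(=O)/C=C/c1ccc(Cn2cnc3c(Nc4cccc(Cl)c4)nc(Cl)nc32)cc1` was tested in a functional assay on HepG2 cells (Homo sapiens) for antiproliferative activity, read by CCK-8 assay, with a stated time of 72 h, tested at 2 uM (a lower number here means a weaker effect, a higher number a stronger effect of the compound at the concentration tested), where compound 1 gives 35.8%. Compound 2 `CCC(C)n1cnc2c(NCc3ccc(C(=O)Nc4ccccc4N)cc3)nc(Cl)nc21` gives 45% in this assay, a number within the usual scatter of that of compound 1, while compound 3 `Nc1ccccc1NC(=O)/C=C/c1ccc(COCNc2nc(Nc3cccc(Cl)c3)c3ncn(C4CCCC4)c3n2)cc1` gives 9.67%, a number beyond the scatter and lower than that of compound 1. Compound 1 thus stands second of the three on the numbers shown, and no step between measured compounds is available to calibrate any change. Compound 4 `Nc1ccccc1NC(=O)/C=C/c1ccc(Cn2cnc3c(Nc4cccc(OC(F)(F)F)c4)nc(Cl)nc32)cc1` differs from compound 1 in one place: trifluoromethoxy in place of chloro on an aromatic carbon. For the measured compounds named here, no measured pair shows what this change does, so only a small step is expected, a number 2.2 percentage points higher from compound 1 to compound 4 (within the scatter), with no direction beyond the scatter. In this assay compound 4 is estimated at 38%, in the range 20% to 56%.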

Compound 4, a percentage reported as inhibition, at one concentration (the size of the read-out at that concentration, not a potency): 16.2%
Beside the measured number, compound 4's estimate is 21.8 percentage points above it, and the stated range ends above it.
By their numbers in this assay, from the lowest: compounds 3 and 4 (each within the scatter of the next); then compounds 1 and 2 (each within the scatter of the next).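

Trifluoromethoxy in place of chloro on this aromatic carbon, meta to a large group, gives a number 19.6 percentage points lower from compound 1 to compound 4 (beyond the scatter) in this assay. For the compounds shown here, this is the first single-place step here, and it shows that the read-out at this position depends on the group it carries, though it rests on one pair alone. No measurement shown here accounts for the change.

The compounds shown leave open how a methoxy group, an amine or a carboxylic acid would read on this carbon. They also leave open whether the same exchange would give a similar step in compound 3, which carries the same 3-chlorophenyl group.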